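The compounds below may be only part of what the source reports. "The series", "measured", "known", "first", "only" and "open" are said of these compounds alone.

Measured in a toxicity assay on MCF-10A cells (Homo sapiens) for cytotoxicity, read by MTT assay, with a stated time of 48 h; on this read-out lower numbers stand for stronger inhibition and higher numbers for weaker inhibition:
compound 1, `O=C(/C=C/c1ccc2c(c1)B(O)OC2)c1ccco1` — 7400 nM
compound 2, `O=C(/C=C/c1ccc2c(c1)B(O)OC2)c1ccc(F)cc1` — 11800 nM
compound 3, `Nc1ccc(C(=O)/C=C/c2ccc3c(c2)B(O)OC3)cc1` — 19900 nM

Compound 1 has the lowest number of the three in this assay; its step to compound 2 is within the scatter and only its step to compound 3 is beyond it, so compound 1 is not clearly separated from compound 2.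

Compound 4, `Cc1cccc(C(=O)/C=C/c2ccc3c(c2)B(O)OC3)c1`, differs from compound 1 by 3-methylphenyl in place of furan-2-yl on a carbonyl carbon. Going by the values given here, the steps that bear on it are the two other replacements of the furan-2-yl on the same carbonyl carbon: a 1.6-fold higher number from compound 1 to compound 2 (0.20 log units; within the scatter) and a 2.7-fold higher number from compound 1 to compound 3 (0.43 log units; beyond the scatter). Both moved the number upward, one within and one beyond the scatter. A small upward step is therefore expected, a 1.5-fold higher number from compound 1 to compound 4 (0.17 log units; within the scatter), probably landing near compound 2. Compound 4 is estimated at 11000 nM, with a range of 5000 nM to 24000 nM.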

Compound 4, half-maximal inhibitory concentration: 15900 nM
Estimate against measurement, compound 4: 1.4-fold (0.16 log units) below; measured number inside the range.
By their numbers in this assay, from the lowest: compounds 1, 2, 4 and 3 (each within the scatter of the next, the first and the last beyond it).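

In this assay, 3-methylphenyl in place of furan-2-yl gives a 2.1-fold higher number from compound 1 to compound 4 (0.33 log units; beyond the scatter), so a replacement with no amino group also moves beyond the scatter, while compound 2 goes against any general shift. The substituted phenyl groups remain unseparated, with a 1.3-fold higher number from compound 2 to compound 4 (0.13 log units; within the scatter) and a 1.3-fold lower number from compound 3 to compound 4 (0.10 log units; within the scatter); the substituent on the phenyl ring therefore shows no readable effect here.

No measured evidence accounts for these steps. As far as these compounds go, whether a thiophen-2-yl or pyridinyl group on the same carbonyl carbon would fall with compound 1 or with compound 4 remains open.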